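A few compounds are considered here, and "the series" means these few. Any claim that something is new, unique, unknown or untested is made for them only; others in the source may bear on it.

Measured compounds in a toxicity assay on NIH3T3 cells (Mus musculus) for cytotoxicity, read by resazurin assay; a lower number here means that less compound is needed, a higher number that more compound is needed for the effect:
compound 1 `N#Cc1ccc(NCc2cncn2Cc2ccc(-c3ccccc3)cc2)cc1-c1ccccc1` — compound 1 gives > 1000 nM, a limit.
compound 2 `COC(=O)c1ccc(NCc2cncn2Cc2ccc(-c3ccccc3)cc2)cc1` — compound 2 gives > 10000 nM, a limit.
compound 3 `Nc1cc(-c2ccccc2)ccc1Cn1cncc1CNc1ccc(-c2nc3ccccc3s2)c(-c2ccccc2)c1` — compound 3 gives > 1000 nM, a limit.

Compound 1 stands only at a limit in this assay, and no number sits anywhere in the set: the limit of > 1000 nM in this assay, at which 2 of the 3 values shown sit, and the limit of > 10000 nM in this assay, at which 1 of the 3 values shown sits, cover all three values. No pair of these compounds differs in a single place, so no measured step is available.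

Compound 4 `c1ccc(-c2ccc(Cn3cncc3CNc3ccc(-c4onc5ccccc45)c(-c4ccccc4)c3)cc2)cc1` is the unmeasured case. Against compound 1 the change is a group of 9 heavy atoms (7 carbon, 1 nitrogen, 1 oxygen; one five-membered aromatic ring with 2 hetero atoms, one six-membered aromatic ring of carbon only) in place of a group of 2 heavy atoms (1 carbon, 1 nitrogen; no ring), on an aromatic carbon. Compound 3 already carries a large bicyclic group at the corresponding position and still sits at a limit; this gives no sign that a group of this kind pulls the value down into the measurable range.

The step from compound 1 to compound 4 in this assay is expected to be none beyond the scatter, most likely another limit, a step that the limit leaves unreadable from compound 1 to compound 4. Compound 4 is therefore estimated at 3000 nM, with a range from 1000 nM to 30000 nM.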

Compound 4, half-maximal effective concentration: > 10000 nM
Compound 4 gave a limit, no number (the forecaster's own chance of this, stated with the estimate: 75%); at least 3.3-fold (0.52 log units) between middle value and limit.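

In this assay, among the compounds shown here, compound 1 and compound 4 both stand only at limits, so no step between them can be read. The compounds shown leave open the concentration at which any of them reaches the half-maximal effect, and whether replacing cyano on compound 1 changes it.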